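A few compounds are considered here, and "the series" means these few. Any claim that something is new, unique, unknown or untested is made for them only; others in the source may bear on it.

Compound 3 `COc1ccc(-c2ccc3c(c2)C(=O)C(=O)N3Cc2ccc(F)cc2)cc1` gives 560 nM in a functional assay on K562 cells (Homo sapiens) for antiproliferative activity, read by MTT assay, with a stated time of 48 h (a lower number here means a stronger inhibitor, a higher number a weaker inhibitor), the lowest number among the measured compounds. Its nearest neighbour is compound 1 `COc1ccc(-c2ccc3c(c2)C(=O)C(=O)N3)cc1`, which gives 6920 nM in this assay; the step of a 12-fold lower number from compound 1 to compound 3 (1.09 log units; beyond the scatter) came from putting 4-fluorobenzyl in place of hydrogen on an amide-type nitrogen in a ring. Compound 2 `COc1ccc(-c2ccc3c(c2)C(=O)C(=O)N3c2ccc(OC)cc2)cc1` gives > 10000 nM in this assay, which is the limit of > 10000 nM in this assay, at which 1 of the 3 values shown sits, rather than a number. Compound 4 `COc1ccc(-c2ccc3c(c2)C(=O)C(=O)N3Cc2ccc(Br)cc2)cc1` differs from compound 3 by bromo in place of fluoro on an aromatic carbon. Going by the values given here, no measured step touches that place: the steps of an at least 1.4-fold higher number from compound 1 to compound 2 (0.15 log units; that floor lies within the scatter) and an at least 17-fold lower number from compound 2 to compound 3 (1.25 log units; beyond the scatter) concern the whole group on the amide-type nitrogen, not a halogen on its benzyl ring. Compound 4 is therefore expected to stay close to compound 3, with a 1.1-fold lower number from compound 3 to compound 4 (0.05 log units; within the scatter) lying within the scatter. The estimate for compound 4 is 500 nM, ranging from 180 nM to 1500 nM.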

Compound 4, half-maximal inhibitory concentration: 100 nM
Estimate against measurement, compound 4: 5.0-fold (0.70 log units) above; measured number outside the range, below it.
By their numbers in this assay, from the lowest: compound 4; then compound 3; then compound 1. At a limit, above all of these: compound 2.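

In this assay the halogen on the benzyl ring counts by itself: bromo in place of fluoro, with nothing else changed, gives a 5.6-fold lower number from compound 3 to compound 4 (0.75 log units; beyond the scatter) and so this place on the ring is not a silent one. Putting 4-bromobenzyl in place of hydrogen gives a 69-fold lower number from compound 1 to compound 4 (1.84 log units; beyond the scatter) and putting it in place of 4-methoxyphenyl gives an at least 100-fold lower number from compound 2 to compound 4 (2.00 log units; beyond the scatter) as a floor only. Compound 2 stands at a limit and not at a number: the limit of > 10000 nM in this assay, at which 1 of the 4 values shown sits.

As far as these compounds go, what chloro, iodo or an amine at this same place would give remains open.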